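A few compounds are considered here, and "the series" means these few. Any claim that something is new, unique, unknown or untested is made for them only; others in the source may bear on it.

Three related compounds have been read so far in a functional assay on MT4 cells (Homo sapiens) for cytotoxicity (on this read-out lower numbers stand for stronger inhibition and higher numbers for weaker inhibition), and they spread widely. Compound 1 (`N#Cc1c(N)cccc1[S+]([O-])c1ccc(Br)cc1`) is reported as > 200000 nM and this is a limit of the assay, not a number. Compound 2 (`COc1ccccc1S(=O)(=O)c1cccc(N)c1C#N`) gives 146000 nM in this assay while compound 3 (`CCOc1cc(C)cc(S(=O)(=O)c2cccc(N)c2C#N)c1`) gives 9000 nM as the lower of the two true numbers, and the gap between them lies beyond the usual scatter of repeat measurements.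

Compound 4 (`CCCCOc1cc(C)cc(S(=O)(=O)c2cccc(N)c2C#N)c1`) departs from compound 3 in one place (ethyl in place of hydrogen on a saturated chain carbon, two bonds along the chain from an oxygen on an aromatic ring): ethyl in place of hydrogen on a saturated chain carbon, two bonds along the chain from an oxygen on an aromatic ring, so that ethoxy becomes butoxy. Among the measured compounds shown here, no measured pair in this set shows what lengthening this chain does, so the forecast is a loose one. It starts from compound 3 at 9000 nM as the closest measured structure, and a change this small is expected to shift the number only modestly. The expected step (a 1.5-fold lower number from compound 3 to compound 4 (0.18 log units; within the scatter)) is a slight estimated move toward a lower number, one that may well stay within the scatter. Compound 4 is estimated at 6000 nM with an expected range (1800 nM to 22000 nM).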

Compound 4, half-maximal inhibitory concentration: > 2000 nM
Compound 4 was reported as a limit; the forecaster's own chance of this, stated with the estimate: 5%; the middle value does not contradict the limit.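

Compound 4 is reported in this assay as > 2000 nM, which is a limit of the assay and not a number. The size of the step between compound 3 and compound 4 cannot be read from this result. The compounds shown leave open whether changing ethoxy to butoxy moves the read-out at all, and in which direction.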